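Swapping an amide for a fluorinated ester on the shared core

A few compounds are considered here, and "the series" means these few. Any claim that something is new, unique, unknown or untested is made for them only; others in the source may bear on it.

Compound 1 `O=C(NC1CCC(CN2CCN(c3cc(=O)c4cc(C(F)(F)F)cc([N+](=O)[O-])c4s3)CC2)CC1)c1ccccc1` is assessed in an ADME assay on cells (Hepatocyte, Mus musculus) for metabolic stability; a lower number here means that the compound disappears faster, a higher number that the compound lasts longer. In this assay compound 1 reaches only the limit of the assay, > 1.55 h, so the hit is the limit of > 1.55 h in this assay, at which 1 of the 2 values shown sits, rather than a number. Compound 2 `O=C(OC1CCC(CN2CCN(c3cc(=O)c4cc(C(F)(F)F)cc([N+](=O)[O-])c4s3)CC2)CC1)c1ccc(C(F)(F)F)cc1` shows 0.278 h in this assay. Compound 3 `O=C(OC1CCC(CN2CCN(c3cc(=O)c4cc(C(F)(F)F)cc([N+](=O)[O-])c4s3)CC2)CC1)c1ccc(F)cc1` differs from compound 1 by ((4-fluorophenyl)carbonyl)oxy in place of benzamido on a saturated ring carbon. For the measured compounds named here, no measured step covers this change; a drop beyond the usual scatter is expected for the step of an at least 3.8-fold lower number from compound 1 to compound 3 (0.58 log units; beyond the scatter), since compound 2 carries a related ester and gives 0.278 h. Compound 3 is therefore estimated at 0.4 h, in the range 0.15 h to 1 h.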

Compound 3, half-life: 0.0817 h
Beside the measured number, compound 3's estimate is 4.9-fold (0.69 log units) above it, and the stated range ends above it.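

In this assay compound 1 gives > 1.55 h, which is a limit of the assay and not a number. Even read from that limit, ((4-fluorophenyl)carbonyl)oxy in place of benzamido on a saturated ring carbon is a large change, giving an at least 18-fold lower number from compound 1 to compound 3 (1.27 log units; beyond the scatter). Within the esters the aromatic substituent also counts: fluoro in place of trifluoromethyl on an aromatic carbon gives a 3.4-fold lower number from compound 2 to compound 3 (0.53 log units; beyond the scatter). Still open, going by these compounds, is how a methoxy group or a chlorine on that aromatic carbon would stand. Also open, on these data alone, is whether an amide carrying fluoro would stay close to compound 1.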